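The source may hold more compounds than are shown below. What is called first, only, known or untested is meant among the compounds shown, and "the series" means these compounds.

Measured so far:
- compound 1 `CC1(C)C=C(n2ccccc2=O)c2cc(S(=O)(=O)NCCO)ccc2O1`: 1000 nM
- compound 2 `CN(c1ccccc1)S(=O)(=O)c1ccc2c(c1)C(n1ccccc1=O)=CC(C)(C)O2`: 9.77 nM

Going by the values given here, compound 1 holds the highest number of the two in a functional assay with Rattus norvegicus as the target; a lower number here means that less compound is needed, a higher number that more compound is needed for the effect; compound 2 sits a 100-fold lower number from compound 1 to compound 2 (2.01 log units; beyond the scatter) away, the only step recorded in this assay. That step exchanged (2-hydroxyethyl)amino for methyl(phenyl)amino on a sulfonyl sulfur and was large and well beyond the scatter.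

Compound 3 `CC1(C)C=C(n2ccccc2=O)c2cc(S(=O)(=O)c3ccccc3)ccc2O1` is not yet measured. It differs from compound 1 as follows: phenyl in place of (2-hydroxyethyl)amino on a sulfonyl sulfur. Compared with the change that produced compound 2, compound 3 also brings in a six-membered aromatic ring of carbon only at the sulfonyl sulfur, but without the nitrogen of the methyl(phenyl)amino group; the sulfur is joined directly to phenyl, and both hydrogen-bond donors of the leaving group are gone.

The step to compound 2 is the only one that bears on this change, and it points to a lower number. With the missing nitrogen the expectation is a smaller gain than that step, so compound 3 is expected at a 20-fold lower number from compound 1 to compound 3 (1.30 log units; beyond the scatter) in this assay. The estimate for compound 3 is 50 nM, with a range from 10 nM to 300 nM.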

Compound 3, half-maximal effective concentration: 182 nM
Compound 3: middle estimate off by 3.6-fold (0.56 log units), on the low side, and the stated range covers the measured number.
By their numbers in this assay, from the lowest: compound 2; then compound 3; then compound 1.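

In this assay the change to phenyl gives a 5.5-fold lower number from compound 1 to compound 3 (0.74 log units; beyond the scatter) with no nitrogen on the sulfonyl sulfur, so a lower number than that of compound 1 does not depend on keeping a nitrogen at this place. The phenyl group alone still falls short of methyl(phenyl)amino, with a 19-fold higher number from compound 2 to compound 3 (1.27 log units; beyond the scatter) in the same assay, which leaves compound 2 with the lowest number of the three and shows that the group attached through nitrogen adds to what the phenyl ring gives. The data offer no explanation for either step.

The shown compounds do not separate the contribution of the nitrogen from that of its methyl group, and phenylamino on the sulfonyl sulfur would be the direct comparison with methyl(phenyl)amino. On these data alone, it also remains open whether a ring is needed at this place at all, a question that a plain methyl or a dimethylamino group on the sulfonyl sulfur would address.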